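From 4-methylphenyl to 2-bromophenyl on a sulfonamide nitrogen

This account rests on a few compounds, and the source may have more. Where it says the series, first, only, none or still open, it means among the compounds named here.

Values in a functional assay on MCF7 cells (Homo sapiens) for antiproliferative activity, read by MTT assay, with a stated time of 72 h (a lower number here means a stronger inhibitor, a higher number a weaker inhibitor), follow
- Compound 1 `CCN(c1ccccc1)S(=O)(=O)C1CC2OC1C(c1ccc(NC(=O)CCCCCCC(=O)O)cc1)=C2c1ccc(O)cc1` gives 19100 nM
- Compound 2 `CCN(c1ccc(C)cc1)S(=O)(=O)C1CC2OC1C(c1ccc(NC(=O)CCCCCCC(=O)O)cc1)=C2c1ccc(O)cc1` gives 42300 nM
- Compound 3 `CCN(c1ccccc1Cl)S(=O)(=O)C1CC2OC1C(c1ccc(NC(=O)CCCCCCC(=O)O)cc1)=C2c1ccc(O)cc1` gives 33300 nM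

The number for compound 2 lies near that of compound 3 (a 1.3-fold lower number from compound 2 to compound 3 (0.10 log units; within the scatter)) and apart from that of compound 1 (a 2.2-fold higher number from compound 1 to compound 2 (0.35 log units; beyond the scatter)). Compound 4 `CCN(c1ccccc1Br)S(=O)(=O)C1CC2OC1C(c1ccc(NC(=O)CCCCCCC(=O)O)cc1)=C2c1ccc(O)cc1` differs from compound 2 by 2-bromophenyl in place of 4-methylphenyl on a sulfonamide nitrogen and carries 2-bromophenyl in place of 4-methylphenyl on a sulfonamide nitrogen. The closest guides are the steps to compound 3, which carries 2-chlorophenyl (a 1.3-fold lower number from compound 2 to compound 3 (0.10 log units; within the scatter)) and (a 1.7-fold higher number from compound 1 to compound 3 (0.24 log units; within the scatter)), both within the scatter. In this assay no step beyond the scatter is therefore expected, and the estimated step is small (a 1.2-fold lower number from compound 2 to compound 4 (0.07 log units; within the scatter)). The estimate for compound 4 is 36000 nM (expected range 18000 nM to 70000 nM).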

Compound 4, half-maximal inhibitory concentration: > 100000 nM
Compound 4: only a limit was reported; the forecaster's own chance of this, stated with the estimate: 3%; middle value at least 2.7-fold (0.44 log units) away from the limit.
By their numbers in this assay, from the lowest: compounds 1, 3 and 2 (each within the scatter of the next, the first and the last beyond it). At a limit, above all of these: compound 4.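

In this assay, compound 4 gives only a limit, > 100000 nM. All three steps to it lie beyond the scatter: an at least 2.3-fold higher number from compound 2 to compound 4 (0.37 log units; beyond the scatter), an at least 3.0-fold higher number from compound 3 to compound 4 (0.47 log units; beyond the scatter) and an at least 5.2-fold higher number from compound 1 to compound 4 (0.71 log units; beyond the scatter). Among these compounds, the earlier changes on this aromatic ring moved the number only modestly or stayed within the scatter, so bromo in place of chloro is the first change here to give a limit rather than a number. As far as these compounds go, how far the true value of compound 4 lies from that limit remains open. So does whether iodo or methoxy in place of the bromo would give a measurable number.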